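Compound 4: a 2-cyanoethenyl group on the shared core

The compounds below may be only part of what the source reports. "The series", "measured", "known", "first", "only" and "open" are said of these compounds alone.

Compound 3 `CSCc1ccc(-c2cnc(C(=O)CCCCCCc3ccccc3)o2)nc1` gives 11.1 nM in an assay for inhibition of Fatty-acid amide hydrolase 1 (Rattus norvegicus), using a Dixon plot (a lower number here means a stronger inhibitor, a higher number a weaker inhibitor), the highest number among the three measured compounds. Compound 1 `O=Cc1ccc(-c2cnc(C(=O)CCCCCCc3ccccc3)o2)nc1` gives 2.2 nM and compound 2 `COCOCc1ccc(-c2cnc(C(=O)CCCCCCc3ccccc3)o2)nc1` gives 10.1 nM. The two steps from compound 1 are of similar size: a 4.6-fold higher number from compound 1 to compound 2 (0.66 log units; beyond the scatter) and a 5.0-fold higher number from compound 1 to compound 3 (0.70 log units; beyond the scatter); the pair of larger groups lie close to each other, a 1.1-fold higher number from compound 2 to compound 3 (0.04 log units; within the scatter).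

Compound 4 `N#C/C=C/c1ccc(-c2cnc(C(=O)CCCCCCc3ccccc3)o2)nc1` carries the change (2-cyanoethenyl in place of (methylsulfanyl)methyl on an aromatic carbon), on an aromatic carbon of a six-membered aromatic ring with 1 nitrogen, two atoms from the ring nitrogen. Within the data shown here, no measured step exchanges one of the larger groups for a group holding a double bond and a triple bond outside aromatic rings, so the two steps from compound 1 bear only loosely: both show that a group other than formyl at this carbon raises the number modestly. The expectation for compound 4 is a number near that of compound 3, perhaps somewhat lower, a 1.9-fold lower number from compound 3 to compound 4 (0.27 log units; within the scatter). Compound 4 is estimated at 6 nM, with a range from 2 nM to 20 nM.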

Compound 4, inhibition constant: 2.1 nM
The estimate for compound 4 lay 2.9-fold (0.46 log units) above the measured number; the range from low to high includes it.
By their numbers in this assay, from the lowest: compounds 4 and 1 (each within the scatter of the next); then compounds 2 and 3 (each within the scatter of the next).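

At this carbon, two atoms from the ring nitrogen, 2-cyanoethenyl stands apart from both (methylsulfanyl)methyl (a 5.3-fold lower number from compound 3 to compound 4 (0.72 log units; beyond the scatter)) and (methoxymethoxy)methyl (a 4.8-fold lower number from compound 2 to compound 4 (0.68 log units; beyond the scatter)) in this assay. The earlier compounds shown here showed only rises on leaving formyl, but 2-cyanoethenyl and formyl cannot be told apart (a 1.0-fold lower number from compound 1 to compound 4 (0.02 log units; within the scatter)), so replacing formyl at this carbon need not raise the number. No measurement on hand explains the difference between these groups.

The compounds shown leave open how a saturated 2-cyanoethyl chain, a bare nitrile, an amine or a carboxylic acid at this carbon would compare, and so whether the double bond or the triple bond matters to the number. They also vary only this one carbon, so nothing here carries over to other carbons of the ring.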